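Replacing 4-Fluorophenyl with Pyridin-3-yl in Compound 2

The compounds below may be only part of what the source reports. "The series", "measured", "known", "first", "only" and "open" are said of these compounds alone.

In an ADME assay on HepG2 cells (Homo sapiens) for cytotoxicity, with a stated time of 72 h (a lower number here means that less compound is needed, a higher number that more compound is needed for the effect), compound 2 `Cc1cc(NC(=O)Nc2ccc(F)cc2)c2ccccc2n1` gives > 25000 nM, which is a limit and not a number. Compound 2 stands at the limit of > 25000 nM in this assay, at which 2 of the 3 values shown sit. Compound 1 `Cc1ccc(NC(=O)Nc2cc(C)nc3ccccc23)cc1` gives > 25000 nM, also a limit. Compound 3 `COC(=O)c1ccc(NC(=O)Nc2cc(C)nc3ccccc23)cc1` gives 20000 nM, a true number.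

Compound 4 `Cc1cc(NC(=O)Nc2cccnc2)c2ccccc2n1` carries pyridin-3-yl in place of 4-fluorophenyl on an amide-type nitrogen. Going by the values given here, no measured step makes this exact swap. The closest are a step that the two limits leave unreadable from compound 1 to compound 2, then an at least 1.2-fold lower number from compound 1 to compound 3 (0.09 log units; that floor lies within the scatter), and an at least 1.2-fold lower number from compound 2 to compound 3 (0.09 log units; that floor lies within the scatter). The first cannot be read and the other two have floors within the scatter, so no step beyond the scatter is expected in this assay. The estimated step is a step that the limit leaves unreadable from compound 2 to compound 4. The expected value for compound 4 is 30000 nM, within an estimated range from 15000 nM to 60000 nM.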

Compound 4, half-maximal effective concentration: > 25000 nM
Compound 4 gave a limit, no number; the forecaster's own chance of this, stated with the estimate: 80%; the middle value lies beyond the limit too.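

In this assay, compound 1, compound 2 and compound 4 each give only a limit, so no step to compound 4 can be read: the limit of > 25000 nM in this assay, at which 3 of the 4 values shown sit.

The compounds shown leave open whether pyridin-3-yl in place of 4-fluorophenyl changes the true value at all.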